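Cyclopropylsulfonyl in place of isopropylsulfonyl: cytotoxicity notes

A few compounds are considered here, and "the series" means these few. Any claim that something is new, unique, unknown or untested is made for them only; others in the source may bear on it.

Compound 1 `CS(=O)(=O)CCCn1c(Cn2cc(S(C)(=O)=O)c3ccccc32)nc2cc(Cl)ccc21`: in an ADME assay on HEp-2 cells (Homo sapiens) for cytotoxicity, with a stated time of 4 days (a higher number here means that more compound is tolerated, a lower number that less compound is tolerated), compound 1 gives > 100000 nM, a limit of the assay.
Compound 2 `CCS(=O)(=O)c1cn(Cc2nc3cc(Cl)ccc3n2CCCS(C)(=O)=O)c2ccccc12`: in this assay compound 2 gives > 100000 nM, a limit of the assay.
Compound 3 `CC(C)S(=O)(=O)c1cn(Cc2nc3cc(Cl)ccc3n2CCCS(C)(=O)=O)c2ccccc12`: in this assay compound 3 gives > 100000 nM, a limit of the assay.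

For the measured compounds named here, compound 3 stands at the limit shared by all three measured compounds; every value known so far is a limit and not a number (the limit of > 100000 nM in this assay, at which 3 of the 3 values shown sit). The measured steps tell no size: a step that the two limits leave unreadable from compound 1 to compound 2, a step that the two limits leave unreadable from compound 1 to compound 3 and a step that the two limits leave unreadable from compound 2 to compound 3 are each unreadable because both ends sit at the limit.

Compound 4 `CS(=O)(=O)CCCn1c(Cn2cc(S(=O)(=O)C3CC3)c3ccccc32)nc2cc(Cl)ccc21` differs from compound 3 by cyclopropyl in place of isopropyl on a sulfonyl sulfur. The measured steps that changed the group on the sulfonyl sulfur, from hydrogen through methyl to isopropyl, left the readout unchanged at the limit, so no step beyond the scatter is expected here either. The step from compound 3 to compound 4 is estimated as a number no higher from compound 3 to compound 4 (the limit leaves the size open). For compound 4 the expected result is 100000 nM, with a range from 50000 nM to 200000 nM, most likely again reported only as a limit.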

Compound 4, half-maximal cytotoxic concentration: > 100000 nM
Compound 4: a limit, no number; the forecaster's own chance of this, stated with the estimate: 85%; the middle value sits exactly at the limit.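

No step can be read between compound 4 and compounds 1, 2 and 3, because all four sit at the same limit: the limit of > 100000 nM in this assay, at which 4 of the 4 values shown sit.

The compounds shown leave open at what concentration any of them becomes cytotoxic in this assay, and whether the group on the sulfonyl sulfur matters there.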